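A few compounds are considered here, and "the series" means these few. Any claim that something is new, unique, unknown or untested is made for them only; others in the source may bear on it.

Working notes on the series. In a functional assay on MT2 cells (Homo sapiens) for antiproliferative activity, read by MTT assay, with a stated time of 72 h (on this read-out higher numbers stand for weaker inhibition of growth and lower numbers for stronger inhibition of growth), compound 1 `O=C(COc1ccc2c(=O)c(-c3ccccc3)coc2c1)Nc1ccccc1` gives > 10000 nM, which is a limit of the assay and not a number. Going by the values given here, compound 2 `COc1ccc(NC(=O)COc2ccc3c(=O)c(-c4ccccc4)coc3c2)cc1` gives 4550 nM, the only actual number so far in this small set.

The next change leads to compound 3 `O=C(COc1ccc2c(=O)c(-c3ccccc3)coc2c1)Nc1ccc(-c2ccccc2)cc1`: phenyl in place of methoxy on an aromatic carbon. In short, phenyl in place of methoxy on an aromatic carbon, para to a large group.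

Among the compounds with values here, one measured step bears on this. It is an at least 2.1-fold lower number from compound 1 to compound 2 (0.34 log units; beyond the scatter), where methoxy takes the place of hydrogen on that same aromatic carbon. From the compounds shown here alone, this step lies beyond the scatter, but its full size stays open, since it rests on (the limit of > 10000 nM in this assay, at which 1 of the 2 values shown sits). It shows that one substituent at this carbon gave stronger inhibition of growth than hydrogen, yet it says nothing direct about exchanging methoxy for phenyl. No step beyond the scatter is therefore expected in this assay, in either direction, and the uncertainty is wide. The estimated step is a 1.1-fold lower number from compound 2 to compound 3 (0.06 log units; within the scatter). For compound 3 the expected value is 4000 nM, with an estimated range from 1300 nM to 10000 nM.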

Compound 3, concentration for 50% growth inhibition: > 10000 nM
Compound 3: a limit, no number (the forecaster's own chance of this, stated with the estimate: 30%); middle value at least 2.5-fold (0.39 log units) from the limit.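

At this aromatic carbon, phenyl in place of methoxy gives an at least 2.1-fold higher number from compound 2 to compound 3 (0.34 log units; beyond the scatter), so in this assay the presence of a substituent at this carbon does not by itself go with stronger inhibition of growth, and the outcome depends on which group sits there. Compound 3 gives > 10000 nM, which is a limit of the assay and not a number. The step between the two compounds that both stop at a limit cannot be read, and the full size of the step from the methoxy compound to the phenyl compound stays open because of this limit: the limit of > 10000 nM in this assay, at which 2 of the 3 values shown sit.

Methoxy remains the only group at this carbon with an actual number, so one value and two limits cannot show whether the outcome in this series follows any trend across groups. From the compounds shown here alone, whether an amine, a hydroxyl, a carboxylic acid or a longer alkoxy chain such as ethoxy at this same carbon would give a number near that of compound 2, or a further limit, stays open.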